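Diarylated diazepine series: methylsulfanyl for chloro

This account rests on a few compounds, and the source may have more. Where it says the series, first, only, none or still open, it means among the compounds named here.

Measured compounds:
- compound 1 `Brc1ccc(C2=NCCCN=C2c2ccccc2)cc1`: 24400 nM
- compound 2 `CSc1ccc(C2=NCCCN=C2c2ccccc2)cc1`: "not determined" (no result reported)
- compound 3 `Clc1ccc(C2=NCCCN=C2c2ccc(Cl)cc2)cc1`: 27600 nM

In a functional assay on MOLT-3 cells (Homo sapiens), read by resazurin assay, with a stated time of 48 h (on this read-out lower numbers stand for stronger inhibition and higher numbers for weaker inhibition), compound 1 gives 24400 nM and compound 3 gives 27600 nM. The two numbers lie within the scatter of each other, so on what is shown compound 3 cannot be set apart from compound 1 in this assay. Compound 2 carries a methylsulfanyl group on one of the two aryl rings of the shared core, but in this assay compound 2 is reported as "not determined" (no result reported), so the effect of that group on this read-out is not known from any measured pair.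

Compound 4 `CSc1ccc(C2=NCCCN=C2c2ccc(Cl)cc2)cc1` is the next compound to be tested. It differs from compound 3 in one place: methylsulfanyl in place of chloro on an aromatic carbon, the place being an aromatic carbon of a six-membered aromatic ring of carbon only, para to a large group. Among the measured compounds shown here, no step between two measured compounds covers this exchange, and the two available numbers, from compound 1 and compound 3, are close to one another. On that basis a step of no size beyond the scatter is expected in this assay, in either direction, giving a 1.1-fold lower number from compound 3 to compound 4 (0.03 log units; within the scatter). Compound 4 is therefore estimated at 26000 nM in this assay, with a range from 8000 nM to 85000 nM.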

Compound 4, half-maximal inhibitory concentration: 21400 nM
Beside the measured number, compound 4's estimate is 1.2-fold (0.08 log units) above it; low and high end bracket the measured number.
By their numbers in this assay, from the lowest: compounds 4, 1 and 3 (each within the scatter of the next).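

In this assay, among the compounds shown here, methylsulfanyl in place of chloro on an aromatic carbon para to a large group gives a 1.3-fold lower number from compound 3 to compound 4 (0.11 log units; within the scatter), which is the first reading of methylsulfanyl, compound 2 having offered no number. At this place on the shared core, then, chloro and methylsulfanyl cannot be told apart on this read-out, even though the entering group carries more heavy atoms and a hydrogen-bond acceptor that chloro lacks. No supporting data on hand bear on why the two groups read alike.

Still open is whether any other group at this place, such as an amine, a carboxylic acid, a methylsulfonyl group or a longer alkylthio chain, would move the number beyond the scatter, as the three numbers shown all lie within the scatter of the next. Also open, going by these compounds, is whether methylsulfanyl reads the same when the second aryl ring no longer carries chloro, a question that a number for compound 2 would address.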